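The source may hold more compounds than are shown below. What is called first, only, known or untested is meant among the compounds shown, and "the series" means these compounds.

Three compounds share one core and differ only in the group on a saturated chain carbon bound to an aromatic nitrogen. Compound 1 `CCCSc1nc(N/N=C(\C)c2ccccc2O)c2nnn(Cc3ccc(O)cc3)c2n1` gives 7680 nM in a functional assay on MGC-803 cells (Homo sapiens) for antiproliferative activity, read by MTT assay, with a stated time of 72 h; on this read-out lower numbers stand for stronger inhibition and higher numbers for weaker inhibition. Compound 2 `CCCSc1nc(N/N=C(\C)c2ccccc2O)c2nnn(Cc3ccc(F)cc3)c2n1` gives 11000 nM in this assay, and compound 3 `CCCSc1nc(N/N=C(\C)c2ccccc2O)c2nnn(Cc3cccc(Cl)c3)c2n1` gives 6500 nM. Compound 3 has the lowest of the three numbers, yet every gap to it lies within the scatter: a 1.2-fold lower number from compound 1 to compound 3 (0.07 log units; within the scatter) and a 1.7-fold lower number from compound 2 to compound 3 (0.23 log units; within the scatter), and a 1.4-fold higher number from compound 1 to compound 2 (0.16 log units; within the scatter) is just as small. Compound 4 `CCCSc1nc(N/N=C(\C)c2ccccc2O)c2nnn(Cc3ccco3)c2n1` carries the change (furan-2-yl in place of 3-chlorophenyl on a saturated chain carbon bound to an aromatic nitrogen). The two measured steps at the same place, leading into compound 3, both stayed within the scatter, so a change of ring at this position has so far not moved the read-out. The step of a 1.1-fold higher number from compound 3 to compound 4 (0.03 log units; within the scatter) is therefore estimated as essentially flat, with no direction favoured. Compound 4 is expected to give about 7000 nM in this assay, with a range from 3000 nM to 18000 nM.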

Compound 4, half-maximal inhibitory concentration: 4760 nM
Beside the measured number, compound 4's estimate is 1.5-fold (0.17 log units) above it, and the stated range covers the measured number.
By their numbers in this assay, from the lowest: compounds 4, 3, 1 and 2 (each within the scatter of the next, the first and the last beyond it).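

In this assay, for the compounds shown here, the step of a 2.3-fold lower number from compound 2 to compound 4 (0.36 log units; beyond the scatter) is the first at this place, on a saturated chain carbon bound to an aromatic nitrogen, to lie beyond the scatter, though only modestly. The steps of a 1.4-fold lower number from compound 3 to compound 4 (0.14 log units; within the scatter) and a 1.6-fold lower number from compound 1 to compound 4 (0.21 log units; within the scatter) stay within the scatter, so furan-2-yl, a five-membered aromatic ring with 1 hetero atom, separates from 4-fluorophenyl alone and not from 3-chlorophenyl or 4-hydroxyphenyl. The read-out therefore holds when the six-membered ring of carbon only gives way to this smaller ring, and nothing available here accounts for the one gap that opens.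

The compounds shown leave open whether thiophen-2-yl or unsubstituted phenyl at this place would read like furan-2-yl. They also leave open whether an amine or a carboxylic acid on the ring would shift the number further than any group seen so far.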